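The source may hold more compounds than are shown below. What is called first, only, known or untested is meant among the compounds shown, and "the series" means these compounds.

Compound 1 `NS(=O)(=O)NCC1CCN(c2cc(-c3cccc(Cl)c3)ncn2)CC1`: in a functional assay on HT-29 cells (Homo sapiens) for antiproliferative activity, read by sulforhodamine B assay, with a stated time of 48 h (a higher number here means a weaker inhibitor of growth, a lower number a stronger inhibitor of growth), compound 1 gives 47500 nM.
Compound 3 `NS(=O)(=O)NCCC1CCN(c2cc(-c3cccc(Cl)c3)ncn2)CC1`: in this assay compound 3 gives 31600 nM.
Compound 2 `COc1ccccc1-c1cc(N2CCC(CNS(N)(=O)=O)CC2)ncn1`: in this assay compound 2 gives > 100000 nM, which is a limit of the assay rather than a number.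

The cores of compound 1 and compound 3 differ by (sulfamoylamino)methyl in place of sulfamoylamino on a saturated chain carbon bound to a saturated ring carbon. The step of a 1.5-fold lower number from compound 1 to compound 3 (0.18 log units; within the scatter) is within the scatter. From compound 1 to compound 2 the change is 2-methoxyphenyl in place of 3-chlorophenyl on an aromatic carbon, and the step is an at least 2.1-fold higher number from compound 1 to compound 2 (0.32 log units; beyond the scatter). Compound 4 `COc1ccccc1-c1cc(N2CCC(CCNS(N)(=O)=O)CC2)ncn1` has not yet been measured in this assay. It differs from compound 3 by 2-methoxyphenyl in place of 3-chlorophenyl on an aromatic carbon, the same change at the same place. For compound 4 the expected step is a 3.2-fold higher number from compound 3 to compound 4 (0.50 log units; beyond the scatter), which rests on an at least 2.1-fold higher number from compound 1 to compound 2 (0.32 log units; beyond the scatter) reaching the limit (the limit of > 100000 nM in this assay, at which 1 of the 3 values shown sits). Compound 4 is estimated at 100000 nM, between 50000 nM and 300000 nM, and the assay may again report only a limit.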

Compound 4, concentration for 50% growth inhibition: 74300 nM
The estimate for compound 4 lay 1.3-fold (0.13 log units) above the measured number, and the stated range covers the measured number.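

Replacing 3-chlorophenyl with 2-methoxyphenyl gives a 2.4-fold higher number from compound 3 to compound 4 (0.37 log units; beyond the scatter) in this assay, so on both cores the change points toward weaker growth inhibition: the same change on two cores in this assay, an at least 2.1-fold higher number (0.32 log units; beyond the scatter) from compound 1 to compound 2 and a 2.4-fold higher number (0.37 log units; beyond the scatter) from compound 3 to compound 4; the limit leaves it open whether they differ. Compound 2 is reported only as a limit, so the direction carries over between these two cores, but whether the size does cannot be said: the limit of > 100000 nM in this assay, at which 1 of the 4 values shown sits. The chain change on the 2-methoxyphenyl compounds, an at least 1.3-fold lower number from compound 2 to compound 4 (0.12 log units; that floor lies within the scatter), cannot be told apart from the scatter: the same change on two cores in this assay, a 1.5-fold lower number (0.18 log units; within the scatter) from compound 1 to compound 3 and an at least 1.3-fold lower number (0.12 log units; that floor lies within the scatter) from compound 2 to compound 4; the limit leaves it open whether they differ.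

Two cores are too few to show how far this change carries through the series. The compounds shown leave open whether it would hold with a longer chain, or with an amine or a carboxylic acid in place of the sulfamoylamino group.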